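From Difluorophenyl to Chlorophenyl at the Assay Limit

The compounds below may be only part of what the source reports. "The series", "measured", "known", "first", "only" and "open" are said of these compounds alone.

Compound 1 (`C=C[C@@](C)(/C=C/c1ccc(Nc2ccc(OC(F)(F)F)cc2)cc1)CCC=C(C)C`), compound 2 (`C=C[C@@](C)(/C=C/c1ccc(Nc2ccc(F)c(F)c2)cc1)CCC=C(C)C`) and compound 3 (`C=C[C@@](C)(/C=C/c1ccc(Nc2cc(F)cc(F)c2)cc1)CCC=C(C)C`) share one core, and all were measured in a functional assay on Raji cells (Homo sapiens) for cytotoxicity, with a stated time of 72 h (on this read-out higher numbers stand for an effect only at larger amounts of compound and lower numbers for an effect already at smaller amounts), without yielding an exact number. Compound 1 gives > 26000 nM as a limit of the assay. Compound 2 gives > 26000 nM as a limit too. Compound 3 gives > 26000 nM as a limit as well, so it has no exact place among the others. The change to compound 4 (`C=C[C@@](C)(/C=C/c1ccc(Nc2ccc(Cl)cc2)cc1)CCC=C(C)C`) puts 4-chlorophenyl in place of 3,5-difluorophenyl on a nitrogen on an aromatic ring. Among the compounds with values here, the only measured step is a step that the two limits leave unreadable from compound 2 to compound 3 and gives no size to build on. The measured set shows the limit of > 26000 nM in this assay, at which 3 of the 3 values shown sit, and nothing finer. No step beyond the usual scatter is therefore expected in this assay and the estimate is a step that the limit leaves unreadable from compound 3 to compound 4 in no clear direction. For compound 4 the expected value is 30000 nM within an estimated range of 12000 nM to 80000 nM and another limit is likely.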

Compound 4, half-maximal effective concentration: > 26000 nM
Compound 4 gave a limit, no number; the forecaster's own chance of this, stated with the estimate: 85%; the middle value is on the limit's open side.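

Compound 4 also gives only a limit, so its steps from compound 1, compound 2 and compound 3 cannot be read. The compounds shown leave open which group on that nitrogen, if any, would give an exact value in this assay.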